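Turning One Double Bond From Z to E

The source may hold more compounds than are shown below. What is called first, only, known or untested is meant among the compounds shown, and "the series" means these compounds.

In an ADME assay on 184B5 cells (Homo sapiens) for antiproliferative activity, read by sulforhodamine B assay, with a stated time of 72 h (a lower number here means a stronger inhibitor, a higher number a weaker inhibitor), compound 1 (`COc1ccc2nc(Cl)c(/C=C\c3ccc(C(F)(F)F)cc3)cc2c1`) gives 40000 nM and compound 2 (`FC(F)(F)c1cccc(/C=C\c2cc3ccccc3nc2Cl)c1`) gives 6150 nM as the lower of the two numbers, with a gap beyond the scatter. Compound 3 (`FC(F)(F)c1cccc(/C=C/c2cc3ccccc3nc2Cl)c1`) has not yet been measured. It has the same atoms and bonds as compound 2 and differs only in configuration as drawn (the two compounds have the same atoms and bonds and differ only in configuration as drawn: 1 of 1 stereo elements differ; a double bond is drawn Z in compound 2 and E in compound 3). For the measured compounds named here, no measured pair isolates such a change, so the expectation is loose. A moderate weakening in this assay is expected, with an estimated 1.8-fold higher number from compound 2 to compound 3 (0.25 log units; within the scatter) as the likely size. Compound 3 is estimated at 11000 nM (range 2500 nM to 40000 nM).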

Compound 3, half-maximal inhibitory concentration: 24700 nM
The estimate for compound 3 lay 2.2-fold (0.35 log units) below the measured number; the measured number falls inside the stated range.
By their numbers in this assay, from the lowest: compound 2; then compounds 3 and 1 (each within the scatter of the next).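

In this assay, the configuration of the double bond moves the number on its own, with a 4.0-fold higher number from compound 2 to compound 3 (0.60 log units; beyond the scatter), so the Z form is the stronger inhibitor of this pair. Compounds 1 and 2 differ in more than one place and could not show this. The step can be assigned to the double bond alone because nothing else separates the pair: the fact that compounds 2 and 3 differ only in the configuration as drawn.

The compounds shown do not say why configuration matters here. They also leave open whether the Z preference would persist with an amine or a carboxylic acid on the shared core.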